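Third aryl on the shared core: furan-3-yl to pyridin-3-yl

The source may hold more compounds than are shown below. What is called first, only, known or untested is meant among the compounds shown, and "the series" means these compounds.

Measured compounds:
compound 1 `Oc1ccc(-c2cc(-c3ccco3)cc(-c3ccccc3O)n2)cc1` — 83%
compound 2 `Oc1ccc(-c2cc(-c3ccoc3)cc(-c3ccccc3O)n2)cc1` — 30.1%

In an assay on isolated protein for inhibition of DNA topoisomerase 1 (Homo sapiens), with a stated time of 30 min, tested at 100 uM (on this read-out lower numbers stand for a weaker effect and higher numbers for a stronger effect at the one concentration tested), compound 2 stands lowest of the two numbers; its nearest neighbour is compound 1, separated by a number 52.9 percentage points lower from compound 1 to compound 2 (beyond the scatter). Compound 3 `Oc1ccc(-c2cc(-c3cccnc3)cc(-c3ccccc3O)n2)cc1` is not yet measured. It differs from compound 2 in one place: pyridin-3-yl in place of furan-3-yl on an aromatic carbon.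

Within the data shown here, only one measured step exists, and it concerns a different change (the move of the attachment point of a furan ring). It shows that the third aryl group on the shared core matters greatly for this assay, but it gives no direct guide to exchanging furan-3-yl for pyridin-3-yl. Among the measured compounds shown here, no measured pair bears on that exchange, so the direction of a number 9.9 percentage points higher from compound 2 to compound 3 (within the scatter) is not expected to be predictable beyond a wide range. Compound 3 is estimated at 40%, within 15% to 70%.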

Compound 3, a percentage reported as inhibition, at one concentration (the size of the read-out at that concentration, not a potency): 1.5%
Compound 3: the middle estimate sits 38.5 percentage points above what was measured; the whole stated range lies above it.
By their numbers in this assay, from the lowest: compound 3; then compound 2; then compound 1.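

In this assay the position responds to a change of ring as well as to a move of the furan attachment point: pyridin-3-yl in place of furan-3-yl gives a number 28.6 percentage points lower from compound 2 to compound 3 (beyond the scatter) and leaves the hydrogen-bond donor and acceptor counts of the group unchanged. Set against furan-2-yl, the same group gives a number 81.5 percentage points lower from compound 1 to compound 3 (beyond the scatter) and compound 3 is the weakest of the three, with every step among them beyond the scatter. The data hold nothing that accounts for these losses.

The exchange alters ring size and hetero atom together, so the compounds shown do not separate these two changes. From the compounds shown here alone, it remains open how thiophen-2-yl, phenyl or pyridin-2-yl would read at this position, and whether an amine or a carboxylic acid on the ring would change the result.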